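This account rests on a few compounds, and the source may have more. Where it says the series, first, only, none or still open, it means among the compounds named here.

Measured compounds:
compound 1 `Clc1ccccc1C1Cc2nccn2C1` – 19 nM
compound 2 `COc1cccc(C2Cc3nccn3C2)c1` – 578 nM
compound 3 `Clc1ccccc1C1CCc2nc[nH]c2C1` – 276 nM

In a functional assay on CHO cells for agonist activity at Alpha-1A adrenergic receptor (Homo sapiens), read by FLIPR and calcium flux (a higher number here means that more compound is needed for the effect, a lower number that less compound is needed), compound 1 gives 19 nM, the lowest of the three numbers. Compound 3 gives 276 nM, and compound 2 gives 578 nM; both gaps to compound 1 are beyond the usual scatter, so compound 1 counts as the most potent of the three in this assay.

The account now turns to compound 4 `COCc1ccccc1C1Cc2nccn2C1`, which has not yet been measured. Compared with compound 1, it carries the change (methoxymethyl in place of chloro on an aromatic carbon). The chloro group of compound 1 leaves, and a methoxymethyl group, with one hydrogen-bond acceptor, enters at the same aromatic carbon. Among the measured compounds shown here, no pair of measured compounds isolates this exchange, so the direction must be judged from the structures alone.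

The step is expected to be an increase in this assay, moderate but beyond the scatter, because the group entering is larger and differently built than the chloro that gave compound 1 its 19 nM. The expected step from compound 1 to compound 4 is a 7.9-fold higher number from compound 1 to compound 4 (0.90 log units; beyond the scatter). Compound 4 is accordingly estimated at 150 nM, with a range from 40 nM to 600 nM.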

Compound 4, half-maximal effective concentration: 82 nM
Compound 4: the middle estimate sits 1.8-fold (0.26 log units) above what was measured, within the range that was stated.
By their numbers in this assay, from the lowest: compound 1; then compound 4; then compound 3; then compound 2.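

In this assay, the exchange of chloro for methoxymethyl on this aromatic carbon brings a 4.3-fold higher number from compound 1 to compound 4 (0.64 log units; beyond the scatter). Among the compounds shown here, this is the first step here between compounds that differ in one place, and it shows that this position accepts 3 heavy atoms and 1 hydrogen-bond acceptor in place of a single chlorine atom, with a modest rise in the number and activity retained. Nothing at hand explains the rise.

With only chloro and methoxymethyl compared at this carbon, the contributions of the size of the group and of its oxygen remain unseparated. From the compounds shown here alone, whether a methyl, an ethyl, a hydroxymethyl or an aminomethyl group at the same aromatic carbon would lie nearer to chloro or to methoxymethyl remains open.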